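A few compounds are considered here, and "the series" means these few. Any claim that something is new, unique, unknown or untested is made for them only; others in the source may bear on it.

Compound 1, `CCCCCCNc1cncc(C(=O)NCc2ccccc2)n1`, gives > 100000 nM in an ADME assay on HeLa cells (Homo sapiens) for cytotoxicity, read by microscopy, with a stated time of 6 days (on this read-out higher numbers stand for lower toxicity in this test and lower numbers for higher toxicity in this test), which is a limit of the assay and not a number.
Compound 2, `CCCCCCCNc1nccnc1C(=O)NCc1ccccc1`, gives > 100000 nM in this assay, again a limit rather than a number.
Compound 3, `CCCCNc1cncc(C(=O)NCc2ccccc2)n1`, gives > 100000 nM in this assay, also a limit.

On the numbers shown, compound 3 stands only at a limit, and the two other values shown are limits as well, so no compound can be placed above or below another. For the measured compounds named here, the single step between measured compounds, a step that the two limits leave unreadable from compound 1 to compound 3, cannot be read in size because of the limit of > 100000 nM in this assay, at which 3 of the 3 values shown sit.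

Compound 4 is `CCCCCCCCNc1cncc(C(=O)NCc2ccccc2)n1`. Relative to compound 3 the change is butyl in place of hydrogen on a saturated chain carbon, four bonds along the chain from a nitrogen on an aromatic ring. The only measured step that bears on this change is a step that the two limits leave unreadable from compound 1 to compound 3, and it gives no readable size, so nothing shown supports expecting a step beyond the scatter in this assay in either direction. The expectation therefore rests on the limit alone.

Compound 4 is accordingly estimated at 100000 nM, with a range from 25000 nM to 400000 nM, which is expected to correspond to a step of a number no higher from compound 3 to compound 4 (the limit leaves the size open).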

Compound 4, minimum cytotoxic concentration: > 100000 nM
Compound 4 was reported as a limit; the forecaster's own chance of this, stated with the estimate: 70%; the middle value sits exactly at the limit.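

Compound 4 gives no readable step against compound 3 or compound 1, because each comparison sets one limit against another: the limit of > 100000 nM in this assay, at which 4 of the 4 values shown sit.

The compounds shown leave open whether lengthening the chain changes toxicity in this assay at all, since none of them has a value that is an actual number.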